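Dichlorophenyl Analogue Follows Two Inactive Carbamates

The compounds below may be only part of what the source reports. "The series", "measured", "known", "first", "only" and "open" are said of these compounds alone.

Compound 2, `CCC(COc1cccc(Br)c1)OC(=O)NCc1ccccc1`, reaches only the assay's limit in an assay for inhibition of zeta-carotene desaturase, chloroplastic/chromoplastic (Capsicum annuum), using a Dixon plot, with a stated time of 8 h (a higher number here means a weaker inhibitor, a lower number a stronger inhibitor), reported as > 100000 nM. Compound 1, `CCC(COc1ccc(Cl)cc1)OC(=O)NCc1ccccc1`, likewise gives only the limit > 100000 nM in this assay. The step that the two limits leave unreadable from compound 1 to compound 2 cannot be read because both values sit at the limit of > 100000 nM in this assay, at which 2 of the 2 values shown sit. Compound 3, `CCC(COc1cccc(Cl)c1Cl)OC(=O)NCc1ccccc1`, differs from compound 2 by 2,3-dichlorophenyl in place of 3-bromophenyl on an oxygen on a saturated carbon. Among the measured compounds shown here, no measured step bears readably on this change, and the two limits give no direction, so in this assay no step beyond the scatter can be foreseen. Compound 3 is expected to give about 100000 nM, between 30000 nM and 300000 nM, most likely again as a limit. The expected step of a number no higher from compound 2 to compound 3 (the limit leaves the size open) is estimated as none beyond the scatter.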

Compound 3, half-maximal inhibitory concentration: > 100000 nM
Compound 3 gave a limit, no number; the forecaster's own chance of this, stated with the estimate: 85%; the middle value lies on the limit itself.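

In this assay, among the compounds shown here, compound 3 gives the limit > 100000 nM and no step among compound 1, compound 2 and compound 3 can be read: the limit of > 100000 nM in this assay, at which 3 of the 3 values shown sit. The compounds shown leave open whether any phenyl group on the shared core gives a readable value in this assay.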